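Swapping the para-chloro benzamide for a fluoro-methyl variant

The source may report more compounds than this note shows. Statements on the series, on what has been measured and on what is new or still open speak of the compounds shown alone.

Compound 1 `O=C(Nc1cccc(-c2oc3cc(-c4ccc(F)cc4)ccc3c(=O)c2O)c1)c1ccc(Cl)cc1` carries a 4-chlorophenyl on the amide carbonyl. In a functional assay on HCC1937 cells (Homo sapiens) for antiproliferative activity, read by CCK-8 assay, with a stated time of 72 h (on this read-out higher numbers stand for weaker inhibition and lower numbers for stronger inhibition), compound 1 gives 4030 nM, the lowest of the three numbers measured. Compound 2 `O=C(Nc1cccc(-c2oc3cc(-c4ccc(F)cc4)ccc3c(=O)c2O)c1)c1ccc(C(F)(F)F)cc1` gives 7350 nM and compound 3 `O=C(Nc1cccc(-c2oc3cc(-c4ccc(F)cc4)ccc3c(=O)c2O)c1)c1ccc(Br)cc1` gives 8630 nM; the steps of a 1.8-fold higher number from compound 1 to compound 2 (0.26 log units; within the scatter) and a 2.1-fold higher number from compound 1 to compound 3 (0.33 log units; beyond the scatter) show that exchanging chloro for another group on that ring nudges the number up at most modestly. Compound 4 `Cc1cc(C(=O)Nc2cccc(-c3oc4cc(-c5ccc(F)cc5)ccc4c(=O)c3O)c2)ccc1F` makes a related exchange: 4-fluoro-3-methylphenyl in place of 4-chlorophenyl on a carbonyl carbon Because both a 1.8-fold higher number from compound 1 to compound 2 (0.26 log units; within the scatter) and a 2.1-fold higher number from compound 1 to compound 3 (0.33 log units; beyond the scatter) stayed small, the step of a 1.4-fold higher number from compound 1 to compound 4 (0.14 log units; within the scatter) is expected to be small as well, with a slight upward tendency. Compound 4 is therefore estimated at 5500 nM, in a range from 2500 nM to 12000 nM.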

Compound 4, half-maximal inhibitory concentration: 5420 nM
The estimate for compound 4 lay 1.0-fold (0.01 log units) above the measured number; low and high end bracket the measured number.
By their numbers in this assay, from the lowest: compounds 1, 4, 2 and 3 (each within the scatter of the next, the first and the last beyond it).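

Among these compounds, the 4-fluoro-3-methylphenyl group is the first in this set to carry both a fluoro and a methyl on the ring, yet all three new steps lie within the scatter: a 1.3-fold higher number from compound 1 to compound 4 (0.13 log units; within the scatter), a 1.4-fold lower number from compound 2 to compound 4 (0.13 log units; within the scatter) and a 1.6-fold lower number from compound 3 to compound 4 (0.20 log units; within the scatter). On the carbonyl carbon, then, this exchange does not separate compound 4 from any of the other three compounds. Nothing available here offers an explanation for these small steps. The compounds shown leave open how a ring bearing an amine or a carboxylic acid would read at this position.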